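This account rests on a few compounds, and the source may have more. Where it says the series, first, only, none or still open, it means among the compounds named here.

Compound 1, `CCCCCCN1C(=O)[C@H](Cc2ccc(-c3cc(OC)c(OC)c(OC)c3)cc2)N(C)C(=O)[C@@H]1C`: in a functional assay for agonist activity at follicle-stimulating hormone receptor (Homo sapiens), read by a luciferase reporter (a lower number here means that less compound is needed, a higher number that more compound is needed for the effect), compound 1 gives 100 nM.
Compound 2, `CCCCCCN1C(=O)[C@H](Cc2ccc(-c3cccc(CN(CCCC)C(=O)OC)c3)cc2)N(C)C(=O)[C@@H]1C`: compound 2 gives 8.9 nM.
Compound 3, `CCCCCCCCN1C(=O)[C@H](Cc2ccc(-c3cccc(CN(CCCC)C(=O)OC)c3)cc2)N(C)C(=O)[C@@H]1C`: compound 3 gives 2.7 nM.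

Compound 3 has the lowest number of the three. The nearest is compound 2, separated by a 3.3-fold lower number from compound 2 to compound 3 (0.52 log units; beyond the scatter), a change on the chain carried by the ring nitrogen; compound 1 lies furthest away, as its value shows.

Compound 4, `CCCCCCCCN1C(=O)[C@H](Cc2ccc(-c3cccc(CN(CCCC)C(=O)NC)c3)cc2)N(C)C(=O)[C@@H]1C`, differs from compound 3 in one place: methylamino in place of methoxy on a carbonyl carbon. Going by the values given here, none of the measured steps touches this part of the molecule, so nothing measured bears on the change. With no guide either way, a step of no more than the usual scatter is expected, a 1.3-fold higher number from compound 3 to compound 4 (0.11 log units; within the scatter). Compound 4 is therefore estimated at 3.5 nM, with a range from 1 nM to 12 nM.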

Compound 4, half-maximal effective concentration: 1.2 nM
For compound 4 the middle estimate is 2.9-fold (0.46 log units) above the measured one, and the stated range covers the measured number.
By their numbers in this assay, from the lowest: compound 4; then compound 3; then compound 2; then compound 1.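

Replacing methoxy with methylamino on the carbonyl carbon, which turns butyl(methoxycarbonyl)amino into butyl(methylcarbamoyl)amino, gives a 2.3-fold lower number from compound 3 to compound 4 (0.35 log units; beyond the scatter) in this assay. Going by these compounds alone, no earlier step touched this part of the molecule, so this shows that the number responds to a change here and that a group with one hydrogen-bond donor, where methoxy has none, is accepted. No evidence on hand accounts for the step.

On these data alone, whether ethylamino or dimethylamino on the same carbonyl carbon would lower the number further remains open. So does whether methylamino would give a similar step with the hexyl chain of compound 2.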